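This account rests on a few compounds, and the source may have more. Where it says the series, first, only, none or still open, it means among the compounds named here.

Compound 3, with the structure `CC1=C(N2CC2)C(=O)C(C(C)COC(N)=O)=C(N2CC2)C1=O`, is the starting point of this account. In a functional assay on L1210 cells (Mus musculus), with a stated time of 12 days (a higher number here means a more potent compound, by a factor of ten per unit of this negative logarithm, a lower number a less potent compound), compound 3 gives 5.71. Among the three compounds measured so far it stands second highest, closest to compound 1, `CC1=C(N2CC2)C(=O)C(CCCOC(N)=O)=C(N2CC2)C1=O`, which gives 5.93, and furthest from compound 2, `CC1=C(N2CC2)C(=O)C(C2CCCCC2)=C(N2CC2)C1=O`, which gives 5.39. The step from compound 1 to compound 3 is a number 0.22 log units lower from compound 1 to compound 3 (within the scatter), so the two carbamate-bearing chains are not separated in this assay. The compound whose value is not yet known is compound 4, `CCC(OC)C1=C(N2CC2)C(=O)C(C)=C(N2CC2)C1=O`. The change from compound 3 to compound 4 is a group of 5 heavy atoms (4 carbon, 1 oxygen; no ring) in place of a group of 7 heavy atoms (4 carbon, 1 nitrogen, 2 oxygen; no ring), on a double-bonded ring carbon.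

Among the compounds with values here, two measured steps bear on this change, since both remove the carbamate chain from the same double-bonded ring carbon: a number 0.54 log units lower from compound 1 to compound 2 (beyond the scatter) and a number 0.32 log units higher from compound 2 to compound 3 (beyond the scatter). In each case the compound without the carbamate was the less potent. Compound 4 also loses the carbamate, but gains a 1-methoxypropyl group rather than a cyclohexyl, so the analogy is only partial. On that basis a modest fall is expected, a number 0.41 log units lower from compound 3 to compound 4 (beyond the scatter), and compound 4 is estimated at 5.3, within a range from 4.85 to 5.75.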

Compound 4, logarithm of the reciprocal of the active concentration, log(1/C): 5.33
Beside the measured number, compound 4's estimate is 0.03 log units below it; the range from low to high includes it.
By their numbers in this assay, from the lowest: compounds 4 and 2 (each within the scatter of the next); then compounds 3 and 1 (each within the scatter of the next).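

In this assay there is a number 0.06 log units lower from compound 2 to compound 4 (within the scatter) and so the open-chain 1-methoxypropyl group and the cyclohexyl ring are not separated at this double-bonded ring carbon, even though one carries an oxygen and the other is carbon only. Compound 4 also falls clearly short of both carbamate-bearing compounds, with a number 0.38 log units lower from compound 3 to compound 4 (beyond the scatter) and with a number 0.60 log units lower from compound 1 to compound 4 (beyond the scatter) as the wider gap. Among these four compounds, both groups without a carbamate therefore lie beyond the scatter below both groups with one, and no compound goes against that division, which now rests on an open-chain group as well as a ring.

The compounds shown leave open whether the carbamate itself carries this difference or whether a simple hydroxyl, an amine or a carboxylic acid at the end of the same chain would stand with compound 1 and compound 3. They also leave open how a longer chain ending in a carbamate would compare. Nothing measured here accounts for the gap between the two pairs.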